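A few compounds are considered here, and "the series" means these few. Any claim that something is new, unique, unknown or untested is made for them only; others in the source may bear on it.

Measured compounds:
Compound 1, `COc1cc(-c2nn(-c3cccc(NC(=O)Nc4ccc(Cl)c(Cl)c4)c3)cc2-c2ccncc2)ccc1Cl`. In a functional assay on RPMI-8226 cells (Homo sapiens) for inhibition, read by sulforhodamine B assay, with a stated time of 48 h (on this read-out higher numbers stand for lower toxicity in this test and lower numbers for higher toxicity in this test), compound 1 gives > 50000 nM, which is a limit of the assay rather than a number.
Compound 2, `COc1cc(-c2nn(-c3cccc(NC(=O)Nc4cccc(C(F)(F)F)c4)c3)cc2-c2ccncc2)ccc1Cl`. In this assay compound 2 gives > 50000 nM, again a limit of the assay.

Compound 2 therefore has no measured number of its own; it stands at the limit where both values shown sit, namely (the limit of > 50000 nM in this assay, at which 2 of the 2 values shown sit). Among the compounds with values here, the only measured step, a step that the two limits leave unreadable from compound 1 to compound 2, cannot be read in size because the limit of > 50000 nM in this assay, at which 2 of the 2 values shown sit, covers both of its ends, so it tells nothing about how much the amide-type nitrogen's aryl group matters.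

Compound 3, `COc1cc(-c2nn(-c3cccc(NC(=O)c4ccc(Cl)c(C(F)(F)F)c4)c3)cc2-c2ccncc2)ccc1Cl`, has not yet been tested. It differs from compound 2 by 4-chloro-3-(trifluoromethyl)phenyl in place of (3-(trifluoromethyl)phenyl)amino on a carbonyl carbon, so the urea of compound 2 becomes a plain amide while the rest of the shared core is kept. Within the data shown here, no measured step covers this kind of change, and the one step available is unreadable, so no direction can be read from the data. Compound 3 is therefore expected to give about 50000 nM, within 15000 nM to 150000 nM, most likely reported once more only as a limit. The expected step from compound 2, a number no higher from compound 2 to compound 3 (the limit leaves the size open), is an estimate of no change beyond the scatter.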

Compound 3, concentration lethal to 50% of the cells: > 32500 nM
Compound 3: a limit, no number; the forecaster's own chance of this, stated with the estimate: 70%; the middle value lies beyond the limit too.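

In this assay compound 3 gives > 32500 nM, which is a limit of the assay and not a number. Compound 1 and compound 2 also stand at limits, so no step among these three compounds can be read in size. As far as these compounds go, whether replacing the urea with a plain amide, or changing the aryl group, alters the result in this assay at all remains open.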